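Dropping the Terminal Phenyl: What Compound 4 Might Show

The source may hold more compounds than are shown below. What is called first, only, known or untested is meant among the compounds shown, and "the series" means these compounds.

Three compounds share one core and differ only in the group on an aromatic carbon at one end. Compound 1 `CCCc1ccc2[nH]c(-c3ccc4[nH]c(-c5ccc6[nH]cnc6c5)nc4c3)nc2c1` carries a propyl group there; in a functional assay on RPMI 8402 cells (Homo sapiens) for cytotoxicity (on this read-out higher numbers stand for weaker inhibition and lower numbers for stronger inhibition), compound 1 gives 20000 nM. Compound 2 `c1cc(-c2ccc3[nH]c(-c4ccc5[nH]c(-c6ccc7[nH]cnc7c6)nc5c4)nc3c2)ccn1` carries pyridin-4-yl, and in this assay compound 2 gives 2500 nM. Compound 3 `c1ccc(-c2ccc3[nH]c(-c4ccc5[nH]c(-c6ccc7[nH]cnc7c6)nc5c4)nc3c2)cc1` carries phenyl, and in this assay compound 3 gives 580 nM. Compound 3 stands lowest of the three: a 4.3-fold lower number from compound 2 to compound 3 (0.63 log units; beyond the scatter), and a 34-fold lower number from compound 1 to compound 3 (1.54 log units; beyond the scatter), both beyond the scatter.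

Compound 4 `c1ccc2[nH]c(-c3ccc4[nH]c(-c5ccc6[nH]cnc6c5)nc4c3)nc2c1` is the next step. Its change from compound 3 is hydrogen in place of phenyl on an aromatic carbon. Among the compounds with values here, no measured step removes a group outright; the nearest comparisons replace propyl with an aromatic ring: an 8.0-fold lower number from compound 1 to compound 2 (0.90 log units; beyond the scatter) and a 34-fold lower number from compound 1 to compound 3 (1.54 log units; beyond the scatter). Both show that a ring on this carbon goes with a lower number than a short chain. Compound 4 loses the ring entirely, and on that basis compound 4 is expected to show a step of a 17-fold higher number from compound 3 to compound 4 (1.24 log units; beyond the scatter). Compound 4 is therefore estimated at 10000 nM, with a range from 2000 nM to 50000 nM.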

Compound 4, half-maximal inhibitory concentration: 28000 nM
Beside the measured number, compound 4's estimate is 2.8-fold (0.45 log units) below it; the range from low to high includes it.
By their numbers in this assay, from the lowest: compound 3; then compound 2; then compounds 1 and 4 (each within the scatter of the next).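

In this assay, the bare carbon gives up what either ring brings, with hydrogen in place of phenyl (a 48-fold higher number from compound 3 to compound 4 (1.68 log units; beyond the scatter)) and hydrogen in place of pyridin-4-yl (an 11-fold higher number from compound 2 to compound 4 (1.05 log units; beyond the scatter)) both beyond the scatter. Propyl, however, cannot be told apart from hydrogen here (a 1.4-fold higher number from compound 1 to compound 4 (0.15 log units; within the scatter)), which lies within the scatter. The earlier compounds showed only that rings go with lower numbers than propyl; compound 4 adds that, among these four compounds, a group on this carbon goes with a lower number than hydrogen only when that group is one of the two rings, and compound 1 goes against any reading that a substituent alone is enough.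

Nothing available here explains these differences. From the compounds shown here alone, whether an amine, a methoxy group or a phenyl ring bearing a carboxylic acid on this carbon would fall with compound 2 and compound 3 or with compound 1 and compound 4 stays open.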